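Bromo to chloro on the fused ring: working notes

The compounds below may be only part of what the source reports. "The series", "measured", "known", "first", "only" and "open" are said of these compounds alone.

Two compounds of this series have numbers in an assay on isolated protein for inhibition of Ectonucleotide pyrophosphatase/phosphodiesterase family member 1 (Homo sapiens), using Lineweaver-Burk analysis; on this read-out higher numbers stand for weaker inhibition and lower numbers for stronger inhibition. Compound 1 `COc1ccc(NC(=O)CSc2nc3c(N)ncnc3[nH]2)cc1OC` gives 18000 nM in this assay. Compound 2 `COc1ccc(NC(=O)CSc2nc3cc(Br)cnc3[nH]2)cc1OC` gives 10800 nM in this assay, the lowest of the two numbers shown, with compound 1 nearest at a number that lies within the scatter, so the two cannot be ordered. Compound 3 `COc1ccc(NC(=O)CSc2nc3cc(Cl)cnc3[nH]2)cc1OC` has not been measured in this assay; it differs from compound 2 by chloro in place of bromo on an aromatic carbon. Among the measured compounds shown here, no step between two measured compounds of this kind exists, so nothing measured here bears directly on an exchange of one halogen for another. The expected step is small: no move in this assay beyond the scatter in either direction, the estimated step being a 1.1-fold higher number from compound 2 to compound 3 (0.05 log units; within the scatter). Compound 3 is therefore estimated at 12000 nM in this assay, with a range of 5000 nM to 30000 nM.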

Compound 3, inhibition constant: 9780 nM
For compound 3 the middle estimate is 1.2-fold (0.09 log units) above the measured one; the measured number falls inside the stated range.
By their numbers in this assay, from the lowest: compounds 3, 2 and 1 (each within the scatter of the next).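

Among the compounds shown here, the exchange of bromo for chloro gives a 1.1-fold lower number from compound 2 to compound 3 (0.04 log units; within the scatter) in this assay and is the first step between measured compounds that differ in one place. On this aromatic carbon, two atoms from the ring nitrogen, the read-out therefore does not separate chloro from bromo, which the comparison of compound 1 with compound 2 could not show. No measurement on hand offers an explanation for this result.

Going by these compounds, whether a group other than these two halogens on this carbon, such as a nitrile, a carboxylic acid or a longer chain, moves the number beyond the scatter stays open. Fluoro and iodo at this position also remain unknown, so the two halogens shown cannot be taken as a trend across the halogens.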